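Methyl on the imidazole ring of two muscarinic-type agonists

The source may hold more compounds than are shown below. What is called first, only, known or untested is meant among the compounds shown, and "the series" means these compounds.

Compound 1 `CC(=O)N(C)C(C)C#CCn1ccnc1` and compound 3 `CN1CCN(CC#CCn2ccnc2)C1=O` were both tested in a functional assay on the whole organism for agonist activity, with Mus musculus as the target; on this read-out higher numbers stand for an effect only at larger amounts of compound and lower numbers for an effect already at smaller amounts. In this assay compound 1 gives 3 mg/kg. Compound 3 gives 1.4 mg/kg, the lowest of the two numbers recorded here. The difference between the two cores is not broken down here.

Compound 2 `CC(=O)N(C)C(C)C#CCn1ccnc1C` carries methyl in place of hydrogen on an aromatic carbon. For compound 2 this assay reports only a limit, > 100 mg/kg. The step is an at least 33-fold higher number from compound 1 to compound 2 (1.52 log units; beyond the scatter), and the evidence for it is the limit of > 100 mg/kg in this assay, at which 1 of the 3 values shown sits, so the true size of the step is not known.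

Compound 4 `Cc1cncn1CC#CCN1CCN(C)C1=O` has not yet been measured. It carries methyl in place of hydrogen on an aromatic carbon. For the measured compounds named here, this is the same kind of change as the one from compound 1 to compound 2, not the same one: in compound 2 the methyl sits between two ring nitrogen atoms, whereas in compound 4 it sits next to the ring nitrogen and two ring bonds from the ring nitrogen.

The step from compound 3 to compound 4 is expected to be an 11-fold higher number from compound 3 to compound 4 (1.03 log units; beyond the scatter), a loss that rests on an at least 33-fold higher number from compound 1 to compound 2 (1.52 log units; beyond the scatter), but taken as smaller than that step because the limit of > 100 mg/kg in this assay, at which 1 of the 3 values shown sits, leaves the size of the earlier step open and the place of the methyl differs. Compound 4 is thus estimated to give 15 mg/kg, with a range from 3 mg/kg to 100 mg/kg.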

Compound 4, dose for half-maximal effect: > 100 mg/kg
Compound 4: no number, only a limit; the forecaster's own chance of this, stated with the estimate: 30%; middle value at least 6.6-fold (0.82 log units) away from the limit.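

In this assay, methyl in place of hydrogen on an aromatic carbon goes with a large loss on both cores, and on the core of compound 3 the step is an at least 71-fold higher number from compound 3 to compound 4 (1.85 log units; beyond the scatter). This shows that the direction of the change carries over between these two cores, even though the methyl stands at a different place on the ring in each pair, but it does not show whether the loss is equally large on both: the same change on two cores in this assay, an at least 33-fold higher number (1.52 log units; beyond the scatter) from compound 1 to compound 2 and an at least 71-fold higher number (1.85 log units; beyond the scatter) from compound 3 to compound 4; the limit leaves it open whether they differ For compound 4, this assay gives only a limit, > 100 mg/kg, so the true size of the new step remains unknown, and two compounds are too few to support a rule for the wider series: the limit of > 100 mg/kg in this assay, at which 2 of the 4 values shown sit.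

The compounds shown leave open whether the place of the methyl matters on any single core, since neither core appears here with the group at both places. They also leave open how a smaller fluorine atom, a chlorine atom or a longer chain such as ethyl on the same aromatic carbon would read in this whole-organism test.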